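The source may report more compounds than this note shows. Statements on the series, on what has been measured and on what is new or still open speak of the compounds shown alone.

Working notes on the series. Compound 1 `Cc1ccc(S(=O)(=O)NCc2ccc(CNC(=O)c3ccccc3)cc2)cc1` and compound 2 `Cc1ccc(S(=O)(=O)NCc2ccc(CNC(=O)c3ccccc3F)cc2)cc1` share one core and differ at a single aromatic carbon. In an assay on MDA-MB-231 cells for binding affinity to C-X-C chemokine receptor type 4 (Homo sapiens), read by immunofluorescence and microscopy, with stated times of 10 min and 30 min (on this read-out higher numbers stand for an effect only at larger amounts of compound and lower numbers for an effect already at smaller amounts), compound 1 gives > 1000 nM, which is a limit of the assay and not a number. In this assay compound 2 gives 1000 nM. Within the data shown here, compound 2 therefore holds the only number recorded in this assay; the one further value is a limit. The step of a number no higher from compound 1 to compound 2 (the limit leaves the size open), fluoro in place of hydrogen on an aromatic carbon, gives a number no higher, but its size cannot be read because of the limit of > 1000 nM in this assay, at which 1 of the 2 values shown sits.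

Compound 3 `Cc1ccc(S(=O)(=O)NCc2ccc(CNC(=O)c3ccccc3C)cc2)cc1` has not been measured. methyl in place of fluoro on an aromatic carbon Compound 3 thus differs from compound 2 by methyl in place of fluoro on an aromatic carbon. Among the measured compounds shown here, no measured step exchanges methyl for fluoro; the single step recorded starts from a limit and sets no size. For compound 3 the step of no change at the digits printed from compound 2 to compound 3 (within the scatter) is expected to stay within the usual scatter. In this assay compound 3 is estimated at 1000 nM, with a range from 400 nM to 2500 nM, and a real chance that only a limit is reported again.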

Compound 3, effective concentration (reported as EC, without a stated level of effect): 100 nM
Estimate against measurement, compound 3: 10-fold (1.00 log units) above; the whole stated range lies above it.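

This aromatic carbon, ortho to a large group, proves sensitive to which substituent it carries: in this assay, methyl in place of fluoro gives a 10-fold lower number from compound 2 to compound 3 (1.00 log units; beyond the scatter), so two groups of one heavy atom each, with no hydrogen-bond donor or acceptor on either, are not interchangeable here. Methyl in place of hydrogen gives an at least 10-fold lower number from compound 1 to compound 3 (1.00 log units; beyond the scatter), which makes this the first substitution in the series with a step shown as beyond the scatter. The full size of that second step remains open because the comparison starts from a limit on compound 1: the limit of > 1000 nM in this assay, at which 1 of the 3 values shown sits.

The compounds shown leave open whether the lower number is particular to methyl or carries over to a longer chain such as ethyl, to a methoxy group or to chlorine on the same carbon. They also leave open what an amine or a carboxylic acid would do at this carbon, and whether methyl on another carbon of the same ring would give a step of similar size.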